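This account rests on a few compounds, and the source may have more. Where it says the series, first, only, none or still open, it means among the compounds named here.

Compounds measured so far:

Compound 1, `Cc1ccc(S(=O)(=O)N2CCN(c3ccc(C(=O)/C=C/c4ccccc4)cc3)CC2)cc1`: 30.8%
Compound 2, `COc1ccc(S(=O)(=O)N2CCN(c3ccc(C(=O)/C=C/c4ccccc4)cc3)CC2)cc1`: 45.2%
Compound 3, `O=C(/C=C/c1ccccc1)c1ccc(N2CCN(S(=O)(=O)c3ccccc3)CC2)cc1`: 30%

All three share one core and differ only in the group on the outer aromatic ring of the sulfonyl part. In a functional assay on the whole organism (strain Kunming) for inhibition, with Mus musculus as the target, with a stated time of 1 h, at a dose of 40 mg/kg by the oral route (on this read-out higher numbers stand for more inhibition at the one dose given (going by the name of the read-out) and lower numbers for less inhibition), compound 3 gives the lowest of the three numbers, though its gap to compound 1 is small: a number 0.8 percentage points lower from compound 1 to compound 3 (within the scatter). Only compound 2 stands clearly apart, as a number 15.2 percentage points lower from compound 2 to compound 3 (beyond the scatter) shows.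

Compound 4, `O=C(/C=C/c1ccccc1)c1ccc(N2CCN(S(=O)(=O)c3ccc(OC(F)(F)F)cc3)CC2)cc1`, has not yet been measured. It differs from compound 3 by trifluoromethoxy in place of hydrogen on an aromatic carbon.

Among the compounds with values here, two measured steps bear on this change, both adding a group to the same position of compound 3. Adding a methyl gave essentially nothing, a number 0.8 percentage points lower from compound 1 to compound 3 (within the scatter) read in reverse, while adding a methoxy gave a modest gain, a number 15.2 percentage points lower from compound 2 to compound 3 (beyond the scatter) read in reverse. Trifluoromethoxy resembles methoxy in its oxygen link to the ring, but no measured compound carries it, so the direction is uncertain. A small rise, or no step beyond the scatter, is therefore expected in this assay .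

Compound 4 is estimated at 38%, with a range from 22% to 55%, which corresponds to an expected step of a number 8 percentage points higher from compound 3 to compound 4 (within the scatter).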

Compound 4, a percentage reported as inhibition, in the whole organism at one dose (the size of the read-out at that dose, not a potency): 47.4%
Estimate against measurement, compound 4: 9.4 percentage points below, within the range that was stated.
By their numbers in this assay, from the lowest: compounds 3 and 1 (each within the scatter of the next); then compounds 2 and 4 (each within the scatter of the next).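

In this assay, trifluoromethoxy on this aromatic carbon, para to a large group, gives a clear gain over hydrogen (a number 17.4 percentage points higher from compound 3 to compound 4 (beyond the scatter)) and over methyl (a number 16.6 percentage points higher from compound 1 to compound 4 (beyond the scatter)). Methoxy was so far the only group here to stand apart from hydrogen, and among these four compounds the two groups joined to the ring through oxygen now both do, while methyl does not, with no compound going against this. Replacing the methyl on that oxygen with trifluoromethyl leaves the number within the scatter (a number 2.2 percentage points higher from compound 2 to compound 4 (within the scatter)), so in this assay the two oxygen-linked groups cannot be told apart, and nothing shown here offers an explanation for the shared gain.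

Going by these compounds, whether the oxygen link itself matters stays open, since a trifluoromethyl, a chlorine or an amine on the same carbon, or a longer ethoxy chain in place of methoxy, would be needed to separate the link from the rest of the group. The read-out also comes from a single oral dose at a single time, so it leaves open how compound 2 and compound 4 would compare at other doses or times.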